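A few compounds are considered here, and "the series" means these few. Any claim that something is new, unique, unknown or untested is made for them only; others in the source may bear on it.

Measured so far:
compound 1, `COc1cc(N(CC2CC2)c2ccccc2)cnc1C(=O)[C@H]1C[C@@H]1C(=O)O`: 158 nM
compound 2, `COc1cc(N(CC2CC2)c2cccc(C(F)(F)F)c2)cnc1C(=O)[C@H]1C[C@@H]1C(=O)O`: 6.42 nM

In an assay for inhibition of leukotriene C4 synthase (Homo sapiens), read by LC-MS, with stated times of 15 min and 30 min (a lower number here means a stronger inhibitor, a higher number a weaker inhibitor), compound 2 gives the lowest number of the two; its nearest neighbour is compound 1, separated by a 25-fold lower number from compound 1 to compound 2 (1.39 log units; beyond the scatter), the change being trifluoromethyl in place of hydrogen on an aromatic carbon. Compound 3, `COc1cc(N(CC(C)(C)O)c2cccc(C(F)(F)F)c2)cnc1C(=O)[C@H]1C[C@@H]1C(=O)O`, differs from compound 2 by 1-hydroxy-1-methylethyl in place of cyclopropyl on a saturated chain carbon bound to a nitrogen on an aromatic ring. For the measured compounds named here, the one measured step concerns the aromatic ring, whereas this change sits on the chain bound to the nitrogen, so no measured step bears on it; the data offer no guide to its size or direction. Since both carry the trifluoromethyl group, the number for compound 3 is expected to stay in the region of compound 2 rather than of compound 1. A step of a 1.9-fold higher number from compound 2 to compound 3 (0.27 log units; within the scatter) is therefore expected, with a wide range. Compound 3 is estimated at 12 nM in this assay, between 3 nM and 50 nM.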

Compound 3, half-maximal inhibitory concentration: 31.8 nM
Beside the measured number, compound 3's estimate is 2.7-fold (0.42 log units) below it; the range from low to high includes it.
By their numbers in this assay, from the lowest: compound 2; then compound 3; then compound 1.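

Compound 1 and compound 2 differ only on the aromatic ring, so they say nothing about the saturated chain carbon bound to a nitrogen on an aromatic ring. In this assay, this position proves responsive to substitution: 1-hydroxy-1-methylethyl in place of cyclopropyl gives a 5.0-fold higher number from compound 2 to compound 3 (0.69 log units; beyond the scatter), a change that removes the three-membered ring and adds one hydrogen-bond donor and one hydrogen-bond acceptor, while compound 3 still reads 31.8 nM. No evidence is available to explain this step.

This single step cannot separate the loss of the cyclopropyl ring from the entry of the hydroxyl group. A tert-butyl group at the same place would address the first of these, and an amine in place of the hydroxyl would show whether the oxygen itself matters.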